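The source may hold more compounds than are shown below. What is called first, only, known or untested is meant among the compounds shown, and "the series" means these compounds.

Measured compounds:
compound 1 `COc1ccccc1-n1nncc1CN1C(=O)C2(C(C#N)=C(N)Oc3c(N)cc4nc5ccccc5nc4c32)c2ccccc21` gives 28900 nM in a functional assay on MCF7 cells (Homo sapiens) for antiproliferative activity, read by MTT assay, with a stated time of 48 h; on this read-out higher numbers stand for weaker inhibition and lower numbers for stronger inhibition;
compound 2 `N#CC1=C(N)Oc2c(N)cc3nc4ccccc4nc3c2C12C(=O)N(Cc1cnnn1-c1ccc(Cl)cc1Cl)c1ccccc12` gives > 50000 nM in this assay, which is a limit of the assay and not a number;
compound 3 `Cc1cc(C)c(-n2nncc2CN2C(=O)C3(C(C#N)=C(N)Oc4c(N)cc5nc6ccccc6nc5c43)c3ccccc32)c(C)c1` gives > 50000 nM in this assay, again a limit and not a number.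

Compound 3 thus stands at the limit at which two of the three values sit (the limit of > 50000 nM in this assay, at which 2 of the 3 values shown sit). Compound 4 `N#CC1=C(N)Oc2c(N)cc3nc4ccccc4nc3c2C12C(=O)N(Cc1cnnn1-c1c(Cl)cc(Cl)cc1Cl)c1ccccc12` differs from compound 3 in one place: 2,4,6-trichlorophenyl in place of 2,4,6-trimethylphenyl on an aromatic nitrogen. The steps that touch compound 3 are an at least 1.7-fold higher number from compound 1 to compound 3 (0.23 log units; that floor lies within the scatter) and a step that the two limits leave unreadable from compound 2 to compound 3. Compound 2, which carries a dichlorophenyl at the same aromatic nitrogen, also sits at the limit. Compound 4 is therefore expected to remain at or near the limit, with a step that the limit leaves unreadable from compound 3 to compound 4 not readable beyond the scatter. The estimate for compound 4 in this assay is 60000 nM, with a range of 20000 nM to 200000 nM.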

Compound 4, half-maximal inhibitory concentration: 37800 nM
Compound 4: the middle estimate sits 1.6-fold (0.20 log units) above what was measured, and the stated range covers the measured number.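

In this assay, within the data shown here, compound 4 is the first chlorinated phenyl compound here to give a number rather than a limit, but the steps to it remain small: an at least 1.3-fold lower number from compound 3 to compound 4 (0.12 log units; that floor lies within the scatter) and an at least 1.3-fold lower number from compound 2 to compound 4 (0.12 log units; that floor lies within the scatter). Against the 2-methoxyphenyl group, the 2,4,6-trichlorophenyl group gives a 1.3-fold higher number from compound 1 to compound 4 (0.12 log units; within the scatter), so no preference between the two can be read at this aromatic nitrogen. Compound 2 and compound 3 remain limits and not numbers: the limit of > 50000 nM in this assay, at which 2 of the 4 values shown sit.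

Still open, from the compounds shown here alone, is whether a phenyl bearing an amine or a carboxylic acid, or a butyl chain in place of the phenyl, would shift the number beyond the scatter.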